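This account rests on a few compounds, and the source may have more. Where it says the series, first, only, none or still open, it means among the compounds named here.

Measured so far in an ADME assay on HCT-116 cells (Homo sapiens) for cytotoxicity, read by CellTiter-Glo, with a stated time of 72 h; on this read-out lower numbers stand for stronger inhibition and higher numbers for weaker inhibition:
Compound 1 `Cc1cc(C)c(S(=O)(=O)N2CCN(C3CN4CCC3CC4)CC2)c(C)c1`: > 5000 nM
Compound 2 `Cc1cc(C)c(S(=O)(=O)N2CCC(N3CCC(C)CC3)CC2)c(C)c1`: > 5000 nM
Compound 3 `Cc1ccc(-c2ccccc2S(=O)(=O)N2CCC(N3CCC(C)CC3)CC2)cc1`: > 5000 nM

Compound 2 reads > 5000 nM, which is a limit of the assay and not a number. It has no company on a measured scale, as all three compounds share one reading: the limit of > 5000 nM in this assay, at which 3 of the 3 values shown sit. No pair of these compounds differs in one place only, so no measured step guides what comes next.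

Compound 4 `Cc1cc(C)c(S(=O)(=O)N2CCC(N3CCN(C)CC3)CC2)c(C)c1` keeps the rest of compound 2 and carries 4-methylpiperazin-1-yl in place of 4-methylpiperidin-1-yl on a saturated ring carbon.

The expectation rests on (the limit of > 5000 nM in this assay, at which 3 of the 3 values shown sit). With no measured value to suggest a gain or a loss, the expected step in this assay, a number no higher from compound 2 to compound 4 (the limit leaves the size open), is none beyond the usual scatter, in neither direction. For compound 4 the estimated value is 5000 nM, with an expected range of 2500 nM to 10000 nM. A report of only a limit is the likeliest result.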

Compound 4, half-maximal inhibitory concentration: > 5000 nM
Compound 4 was reported as a limit; the forecaster's own chance of this, stated with the estimate: 90%; the middle value lies on the limit itself.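

Among these compounds, compound 2 and compound 4 are both reported in this assay only as limits, not as numbers, and no step between them can be read. The compounds shown leave open whether 4-methylpiperazin-1-yl in place of 4-methylpiperidin-1-yl changes the inhibition at all, since all share one reading: the limit of > 5000 nM in this assay, at which 4 of the 4 values shown sit.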